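Hexyl to Naphthalen-1-yl on the Sulfonyl Sulfur

A few compounds are considered here, and "the series" means these few. Any claim that something is new, unique, unknown or untested is made for them only; others in the source may bear on it.

Three sulfonamides built on one shared core have been tested in a functional assay (thoracic aorta) for inhibition, with Rattus norvegicus as the target; a higher number here means a weaker inhibitor, a lower number a stronger inhibitor. Compound 1 `CCc1ccc(S(=O)(=O)N[C@H]2C3CC[C@H](C3)[C@@H]2C/C=C\CCCC(=O)O)cc1` gives 1.5 nM. Compound 2 `Cc1cccc(S(=O)(=O)N[C@H]2C3CC[C@H](C3)[C@@H]2C/C=C\CCCC(=O)O)c1` gives 3.2 nM. Compound 3 `CCCCCCS(=O)(=O)N[C@H]1C2CC[C@H](C2)[C@@H]1C/C=C\CCCC(=O)O` gives 17.2 nM, the highest of the three numbers; compound 2 stands nearest to it and compound 1 furthest, both beyond the scatter. Compound 4 `O=C(O)CCC/C=C\C[C@H]1[C@@H]2CCC(C2)[C@@H]1NS(=O)(=O)c1cccc2ccccc12` has not yet been measured and differs from compound 3 in one place: naphthalen-1-yl in place of hexyl on a sulfonyl sulfur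

The measured steps that bear on this change are the two in which an aromatic group on the sulfonyl sulfur gave way to the hexyl chain: an 11-fold higher number from compound 1 to compound 3 (1.06 log units; beyond the scatter) and a 5.4-fold higher number from compound 2 to compound 3 (0.73 log units; beyond the scatter). Between the two aromatic groups themselves there was only a 2.1-fold higher number from compound 1 to compound 2 (0.33 log units; beyond the scatter). Compound 4 brings an aromatic group back in place of the hexyl chain, here a naphthalen-1-yl with two six-membered aromatic rings of carbon only. The step from compound 3 to compound 4 is therefore expected to lower the number in this assay by a modest-to-large amount, with an estimated step of a 5.7-fold lower number from compound 3 to compound 4 (0.76 log units; beyond the scatter). Compound 4 is estimated to give 3 nM in this assay, within a range from 1 nM to 10 nM.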

Compound 4, half-maximal inhibitory concentration: 2.7 nM
Beside the measured number, compound 4's estimate is 1.1-fold (0.05 log units) above it; the measured number falls inside the stated range.
By their numbers in this assay, from the lowest: compounds 1, 4 and 2 (each within the scatter of the next, the first and the last beyond it); then compound 3.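

In this assay, the step back from hexyl to naphthalen-1-yl on the sulfonyl sulfur gives a 6.4-fold lower number from compound 3 to compound 4 (0.80 log units; beyond the scatter) and so shows that the hexyl chain falls short of a third aromatic group, this one with two six-membered aromatic rings of carbon only. Among the four compounds shown, compound 3 is the only one without an aromatic group at this position, and all three of its steps to the aromatic compounds lie beyond the scatter. The second ring brings no readable gain or loss over a single ring bearing a small alkyl group, since a 1.2-fold lower number from compound 2 to compound 4 (0.07 log units; within the scatter) and a 1.8-fold higher number from compound 1 to compound 4 (0.26 log units; within the scatter) both lie within the scatter, even though compound 1 and compound 2 can be told apart from each other.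

Going by these compounds, how a pyridine ring, a benzyl group or a shorter chain such as butyl on the sulfonyl sulfur would compare with these groups remains open. The measurements also offer no information that would explain the gap between the hexyl chain and the aromatic groups.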